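Swapping the aryl group on the bridging carbon of compound 1

The source may report more compounds than this note shows. Statements on the series, on what has been measured and on what is new or still open speak of the compounds shown alone.

Compound 1, `Oc1c(C(Nc2ccccn2)c2ccccc2Cl)ccc2cccnc12`, carries a 2-chlorophenyl group on a saturated chain carbon that also bears an aromatic carbon and a nitrogen on an aromatic ring. Going by the values given here, in an assay for inhibition of protein disulfide-isomerase (Homo sapiens), with a stated time of 1 h (on this read-out higher numbers stand for weaker inhibition and lower numbers for stronger inhibition), compound 1 gives 500 nM, the only numerical value among the three measured compounds. Compound 2, `CN(C)c1cccc(C(c2ccc(F)cc2)N2CCCCC2)c1O`, reaches only the assay limit of > 30000 nM. Compound 3, `Oc1cc2c(cc1C(c1ccc(F)cc1)N1CCCCC1)CCCC2`, likewise reaches only the assay limit of > 100000 nM. Among the compounds with values here, no step between measured compounds is available here. Compound 4, `CCc1ccc(C(Nc2ccccn2)c2ccc3cccnc3c2O)cc1`, differs from compound 1 by 4-ethylphenyl in place of 2-chlorophenyl on a saturated chain carbon bound to an aromatic carbon and a nitrogen on an aromatic ring. The step of a 1.6-fold higher number from compound 1 to compound 4 (0.20 log units; within the scatter) is expected to stay close to the scatter, leaning toward weaker inhibition. Compound 4 is therefore estimated at 800 nM, within a range from 250 nM to 3000 nM.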

Compound 4, half-maximal inhibitory concentration: 170 nM
Compound 4: the middle estimate sits 4.7-fold (0.67 log units) above what was measured; measured number below the stated range.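

In this assay, 4-ethylphenyl in place of 2-chlorophenyl gives a 2.9-fold lower number from compound 1 to compound 4 (0.47 log units; beyond the scatter) and so gives stronger inhibition. Going by these compounds alone, this is the first direct reading of this position, on the saturated chain carbon bound to an aromatic carbon and a nitrogen on an aromatic ring, and it shows that the aryl group there can be changed without losing inhibition. Within the data shown here, the single step changes both the group and where it sits on the phenyl ring, so the two changes cannot be told apart.

From the compounds shown here alone, how 2-ethylphenyl, 4-chlorophenyl, or a phenyl ring carrying an amine or a carboxylic acid would compare stays open. Nothing shown explains the direction of this step.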